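A few compounds are considered here, and "the series" means these few. Any claim that something is new, unique, unknown or untested is made for them only; others in the source may bear on it.

Working notes on the series

The shared core is carried by compound 1 `O=C1c2c[n+]([O-])c3ccccc3c2C(=O)c2c1c1ccccc1n2CCCCN1CCNCC1`, compound 2 `CCCN1CCN(CCCCn2c3c(c4ccccc42)C(=O)c2c[n+]([O-])c4ccccc4c2C3=O)CC1` and compound 3 `CN1CCN(CCCCCCn2c3c(c4ccccc42)C(=O)c2c[n+]([O-])c4ccccc4c2C3=O)CC1`. In a functional assay on HCT-116 cells (Homo sapiens) for cytotoxicity, read by MTT assay, with a stated time of 72 h (a lower number here means a stronger inhibitor, a higher number a weaker inhibitor), compound 1 gives 700 nM, compound 2 gives 790 nM and compound 3 gives 2900 nM. Compound 1 thus has the lowest number of the three measured, with compound 2 nearest to it and compound 3 furthest away. The step of a 1.1-fold higher number from compound 1 to compound 2 (0.05 log units; within the scatter) shows that a propyl in place of hydrogen on the amine nitrogen in the ring changes nothing beyond the scatter; the steps of a 4.1-fold higher number from compound 1 to compound 3 (0.62 log units; beyond the scatter) and a 3.7-fold higher number from compound 2 to compound 3 (0.56 log units; beyond the scatter) show a modest loss when the chain is extended to a 2-(4-methylpiperazin-1-yl)ethyl.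

Compound 4 `O=C1c2c[n+]([O-])c3ccccc3c2C(=O)c2c1c1ccccc1n2Cc1cn(C[C@@H](O)CO)nn1` is not yet measured. It differs from compound 1 by 1-(2,3-dihydroxypropyl)-1H-1,2,3-triazol-4-yl in place of 3-(piperazin-1-yl)propyl on a saturated chain carbon bound to an aromatic nitrogen. Within the data shown here, none of the measured steps touches this change: compound 2 and compound 3 both keep a piperazine on the chain, and no compound without one has been tested in this assay. Among the measured compounds shown here, the only guidance is that the one larger change measured, from compound 1 to compound 3, went towards weaker inhibition, and the present change is larger again. A loss of similar or greater size is therefore expected, with a wide range. For compound 4 the estimate in this assay is 3500 nM, between 900 nM and 14000 nM, which means an expected step of a 5.0-fold higher number from compound 1 to compound 4 (0.70 log units; beyond the scatter).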

Compound 4, half-maximal inhibitory concentration: 190 nM
Compound 4: middle estimate off by 18-fold (1.27 log units), on the high side, and the stated range ends above it.
By their numbers in this assay, from the lowest: compound 4; then compounds 1 and 2 (each within the scatter of the next); then compound 3.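

In this assay, among these compounds, the position on a saturated chain carbon bound to an aromatic nitrogen does not depend on a piperazine: 1-(2,3-dihydroxypropyl)-1H-1,2,3-triazol-4-yl in place of 3-(piperazin-1-yl)propyl gives a 3.7-fold lower number from compound 1 to compound 4 (0.57 log units; beyond the scatter) and is the first change at this position to lower the number. The gain also holds against the other two piperazine compounds, with a 4.2-fold lower number from compound 2 to compound 4 (0.62 log units; beyond the scatter) and a 15-fold lower number from compound 3 to compound 4 (1.18 log units; beyond the scatter) as the largest step in the series, so compound 4 has the lowest number of the four, beyond the scatter of each of the others. Nothing available here accounts for this gain.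

The compounds shown leave open whether the lower number follows the triazole ring, the two hydroxyl groups or the shorter link to the core, since all three change together in this one step; a triazole carrying a plain propyl chain or a piperazine in place of the dihydroxypropyl group would separate the first two. Also open, as far as these compounds go, is the role of the defined stereocentre, which the opposite enantiomer of the 2,3-dihydroxypropyl group would test.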